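The source may hold more compounds than are shown below. What is called first, only, known or untested is meant among the compounds shown, and "the series" means these compounds.

Series notes on the cytotoxicity arm. Compound 1 `CS(=O)(=O)Nc1ccc2c(c1)S(=O)(=O)C=C(c1c(O)c3ccccc3n(Cc3ccc(F)cc3)c1=O)N2` is the parent of the set. In an ADME assay on 2209-23 cells (Homo sapiens) for cytotoxicity, read by WST assay (a higher number here means that more compound is tolerated, a lower number that less compound is tolerated), compound 1 gives > 50000 nM, which is a limit of the assay and not a number. Compound 2 `CS(=O)(=O)Nc1ccc2c(c1)S(=O)(=O)C=C(c1c(O)c3c(Cl)cccc3n(Cc3ccc(F)cc3)c1=O)N2` carries a chloro in place of hydrogen on an aromatic carbon. In this assay compound 2 gives > 50000 nM, again a limit. Compound 3 `CS(=O)(=O)Nc1ccc2c(c1)S(=O)(=O)C=C(c1c(O)c3cc(Cl)ccc3n(Cc3ccc(F)cc3)c1=O)N2` likewise carries a chloro in place of hydrogen on an aromatic carbon. In this assay compound 3 gives > 50000 nM, also a limit. The steps a step that the two limits leave unreadable from compound 1 to compound 2 and a step that the two limits leave unreadable from compound 1 to compound 3 therefore cannot be sized; what is known is the limit of > 50000 nM in this assay, at which 3 of the 3 values shown sit. Compound 4 `CS(=O)(=O)Nc1ccc2c(c1)S(=O)(=O)C=C(c1c(O)c3ccc(Cl)cc3n(Cc3ccc(F)cc3)c1=O)N2` is not yet measured. It differs from compound 1 by chloro in place of hydrogen on an aromatic carbon. The two measured chloro steps bear on it, and both are unreadable, so no direction beyond the scatter can be called from them. Because of the limit of > 50000 nM in this assay, at which 3 of the 3 values shown sit, compound 4 is expected to sit at the same limit, with a step that the limit leaves unreadable from compound 1 to compound 4 as the expected step. The estimate for compound 4 in this assay is 80000 nM, between 40000 nM and 200000 nM, with the most likely outcome a limit rather than a number.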

Compound 4, half-maximal cytotoxic concentration: > 50000 nM
Compound 4 was reported as a limit (the forecaster's own chance of this, stated with the estimate: 90%); the middle value lies beyond the limit too.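

No step can be read between compound 1 and compound 4: both stand only as limits in this assay. The compounds shown leave open at what concentration any of them becomes cytotoxic, and whether a chloro in place of hydrogen on an aromatic carbon shifts that concentration at all, with every value at one limit: the limit of > 50000 nM in this assay, at which 4 of the 4 values shown sit.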